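A few compounds are considered here, and "the series" means these few. Any claim that something is new, unique, unknown or untested is made for them only; others in the source may bear on it.

Measured compounds, values in a physicochemical assay for lipophilicity, read by HPLC, in phosphate buffer, measured as octanol-water partition, at pH 7.4; a higher number here means a more lipophilic compound, a lower number a more polar compound:
compound 1, `COc1ccc2c(c1)c(CC(=O)OCOC(=O)C(C)(C)C)c(C)n2C(=O)c1ccc(Cl)cc1` — compound 1 gives 4.7
compound 2, `COc1ccc2c(c1)c(CC(=O)OCOC(=O)OC(C)C)c(C)n2C(=O)c1ccc(Cl)cc1` — compound 2 gives 5
compound 3, `COc1ccc2c(c1)c(CC(=O)OCCOC(C)=O)c(C)n2C(=O)c1ccc(Cl)cc1` — compound 3 gives 3.5

Compound 3 stands lowest of the three numbers in this assay; compound 1 is the nearest and compound 2 the furthest, both separated from it beyond the scatter. The steps already seen at this place are a number 1.20 log units lower from compound 1 to compound 3 (beyond the scatter) and a number 1.50 log units lower from compound 2 to compound 3 (beyond the scatter); between the other two the step is a number 0.30 log units higher from compound 1 to compound 2 (within the scatter). Compound 4, `COc1ccc2c(c1)c(CC(=O)OCc1oc(=O)oc1C)c(C)n2C(=O)c1ccc(Cl)cc1`, differs from compound 3 by a group of 7 heavy atoms (4 carbon, 3 oxygen; one five-membered aromatic ring with 2 hetero atoms) in place of a group of 5 heavy atoms (3 carbon, 2 oxygen; no ring), on a saturated chain carbon bound to an oxygen next to a carbonyl group. Going by the values given here, the two large steps into compound 3 were exchanges at the same position and so bear on this change, but neither is the same exchange, and no measured pair gives the present group directly; the direction is therefore read with caution. The entering group is the larger of the two as counted, and a modest rise in this assay is expected, a number 0.20 log units higher from compound 3 to compound 4 (within the scatter). Compound 4 is estimated at 3.7, with a range from 3.1 to 4.3.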

Compound 4, partition coefficient: 2.9
Estimate against measurement, compound 4: 0.80 log units above; measured number outside the range, below it.
By their numbers in this assay, from the lowest: compound 4; then compound 3; then compounds 1 and 2 (each within the scatter of the next).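

In this assay, the heavy-atom count does not set the direction at this place, on a saturated chain carbon bound to an oxygen next to a carbonyl group: although the entering group is the larger as counted, the step is a number 0.60 log units lower from compound 3 to compound 4 (beyond the scatter). Against the open-chain groups with the same count of heavy atoms, the steps are larger still, a number 2.10 log units lower from compound 2 to compound 4 (beyond the scatter) and a number 1.80 log units lower from compound 1 to compound 4 (beyond the scatter), so that a ring-bearing group of identical atom composition to the group in compound 2 gives the largest step seen in the series, and compound 4 now stands lowest of the four, beyond the scatter from each of the others. No measurement at hand accounts for these steps.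

Going by these compounds alone, with only one ring-bearing group, it remains open whether the lower number goes with the five-membered aromatic ring itself or with the methyl group it carries. Going by these compounds, how an amine or a carboxylic acid at the end of a longer chain would stand at this place is also open.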